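This account rests on a few compounds, and the source may have more. Where it says the series, first, only, none or still open, it means among the compounds named here.

Measured compounds:
Compound 1 `O=S(=O)(NCCCNc1nccc(-c2c(-c3cccc(F)c3)nc3sccn23)n1)c1ccc(F)cc1` gives 14500 nM in a functional assay on A-375 cells (Homo sapiens) for cytotoxicity, read by MTT assay; a lower number here means a stronger inhibitor, a higher number a weaker inhibitor.
Compound 2 `O=S(=O)(NCCNc1nccc(-c2c(-c3cccc(F)c3)nc3sccn23)n1)c1ccc(F)cc1` gives 9450 nM in this assay.
Compound 3 `O=C(NCCNc1nccc(-c2c(-c3cccc(F)c3)nc3sccn23)n1)c1ccc(C(F)(F)F)cc1` gives 8710 nM in this assay.

Compound 1 stands at the upper end of the three numbers, but the step of a 1.5-fold lower number from compound 1 to compound 2 (0.19 log units; within the scatter) is within the scatter, and the two values of compound 1 and compound 3 also lie within the scatter of one another, so no ordering among the three is secure.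

Compound 4 `O=C(NCCNc1nccc(-c2c(-c3cccc(F)c3)nc3sccn23)n1)c1ccc(Cl)cc1` is reached from compound 1 by the change (((4-chlorophenyl)carbonyl)amino in place of (((4-fluorophenyl)sulfonyl)amino)methyl on a saturated chain carbon, two bonds along the chain from a nitrogen on an aromatic ring). For the measured compounds named here, two measured steps bear on it: the shortening of the chain, a 1.5-fold lower number from compound 1 to compound 2 (0.19 log units; within the scatter), and the exchange of the sulfonyl for a carbonyl-linked aryl group, a 1.1-fold lower number from compound 2 to compound 3 (0.04 log units; within the scatter). Both were within the scatter. Going by the values given here, the chloro substituent in place of the trifluoromethyl of compound 3 has no measured counterpart here. Taken together, the step of a 1.6-fold lower number from compound 1 to compound 4 (0.21 log units; within the scatter) is expected to stay within the scatter, with no clear direction. For compound 4 a value of 9000 nM is estimated, in the range 4000 nM to 20000 nM.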

Compound 4, half-maximal inhibitory concentration: 2570 nM
Compound 4: the middle estimate sits 3.5-fold (0.54 log units) above what was measured; measured number below the stated range.
By their numbers in this assay, from the lowest: compound 4; then compounds 3, 2 and 1 (each within the scatter of the next).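

Chloro in place of trifluoromethyl on an aromatic carbon gives a 3.4-fold lower number from compound 3 to compound 4 (0.53 log units; beyond the scatter) in this assay, the first change in the series to go beyond the scatter. The outcome of replacing (4-fluorophenyl)sulfonyl on the amine nitrogen therefore depends on the incoming group: (4-chlorophenyl)carbonyl gives a 3.7-fold lower number from compound 2 to compound 4 (0.57 log units; beyond the scatter) here, whereas (4-(trifluoromethyl)phenyl)carbonyl gives only a 1.1-fold lower number from compound 2 to compound 3 (0.04 log units; within the scatter) for the same kind of exchange. The full change gives a 5.6-fold lower number from compound 1 to compound 4 (0.75 log units; beyond the scatter) as well, and no measurement at hand accounts for these steps.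

From the compounds shown here alone, it remains open whether the gain is specific to chloro or extends to bromo, methyl or methoxy on the same aromatic carbon. Going by these compounds, it is also open whether a (4-chlorophenyl)sulfonyl group, or the ((4-chlorophenyl)carbonyl)amino group on a longer chain, would keep the value of compound 4 at 2570 nM in this assay or lose it.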